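The source may report more compounds than this note shows. Statements on the series, on what has been measured and on what is new or still open speak of the compounds shown alone.

Measured in an ADME assay on BE(2)-C cells (Homo sapiens) for cytotoxicity, read by MTT assay, with a stated time of 20 h; on this read-out lower numbers stand for higher toxicity in this test and higher numbers for lower toxicity in this test:
compound 1 `C[C@@H](NC(=O)C1CCN(C(=O)c2cc3ccccc3n2Cc2ccc(Cl)cc2)CC1)c1ccncc1` (92300 nM)
compound 2 `CN1CCN(C(=O)C2CCN(C(=O)c3cc4ccccc4n3Cc3ccc(Cl)cc3)CC2)CC1` (75600 nM)

Going by the values given here, compound 2 (75600 nM) lies within the scatter of compound 1, the only other measured compound, so the two cannot be ranked. Compound 3 `CN1CCC(CNC(=O)C2CCN(C(=O)c3cc4ccccc4n3Cc3ccc(Cl)cc3)CC2)CC1` has not yet been measured. It carries ((1-methylpiperidin-4-yl)methyl)amino in place of 4-methylpiperazin-1-yl on a carbonyl carbon.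

Among the compounds with values here, only one measured step bears on this change. It exchanged the group at the same place and came to a 1.2-fold lower number from compound 1 to compound 2 (0.09 log units; within the scatter), which is within the scatter. Within the data shown here, that is thin evidence, since it is a single step and no measured compound carries the entering group. On the strength of that step, no shift beyond the scatter is expected in this assay, and no direction can be given. The expected change is a 1.1-fold higher number from compound 2 to compound 3 (0.02 log units; within the scatter), which would leave the estimated value close to the two measured ones. The estimate for compound 3 is 80000 nM, with an expected range from 35000 nM to 170000 nM.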

Compound 3, half-maximal cytotoxic concentration: > 50000 nM
Compound 3 was reported as a limit; the forecaster's own chance of this, stated with the estimate: 15%; the middle value does not contradict the limit.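

In this assay compound 3 gives > 50000 nM and that value is a limit, not a number. Going by these compounds alone, no step from compound 1 or compound 2 to compound 3 can be read. The compounds shown leave open whether ((1-methylpiperidin-4-yl)methyl)amino in place of 4-methylpiperazin-1-yl shifts this read-out at all, and in which direction.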